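Three Compounds at the Limit and One Untested

The source may report more compounds than this note shows. Statements on the series, on what has been measured and on what is new or still open speak of the compounds shown alone.

Compound 1 `COc1ccc(C(=O)/C=C/c2ccc(Br)cc2)c2c1C=CC(C)(C)O2`, compound 2 `COc1ccc(C(=O)/C=C/c2ccco2)c2c1C=CC(C)(C)O2` and compound 3 `COc1ccccc1/C=C/C(=O)c1ccc(OC)c2c1OC(C)(C)C=C2` share one core and differ only in the group on a double-bonded chain carbon bound to a double-bonded chain carbon. In a functional assay on SW-620 cells (Homo sapiens) for antiproliferative activity, read by MTT assay, with a stated time of 24 h (on this read-out higher numbers stand for weaker inhibition and lower numbers for stronger inhibition), compound 1 gives > 10000 nM, which is a limit of the assay and not a number. In this assay compound 2 also gives only the limit > 10000 nM. Compound 3 likewise gives only the limit > 10000 nM in this assay. Because all three values sit at the same limit (the limit of > 10000 nM in this assay, at which 3 of the 3 values shown sit), the steps a step that the two limits leave unreadable from compound 1 to compound 2, a step that the two limits leave unreadable from compound 1 to compound 3 and a step that the two limits leave unreadable from compound 2 to compound 3 cannot be read in size, so compound 3 stands nowhere on a scale of numbers; it simply rests at the limit alongside the other two.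

Compound 4 `COc1ccc(C(=O)/C=C/c2ccc(O)c(Br)c2)c2c1C=CC(C)(C)O2` differs from compound 3 by 3-bromo-4-hydroxyphenyl in place of 2-methoxyphenyl on a double-bonded chain carbon bound to a double-bonded chain carbon. Within the data shown here, no measured step involves a group carrying a hydroxyl, so the swaps seen so far offer no size to lean on; their only bearing is that every exchange of this group left the value at the limit. The step that the limit leaves unreadable from compound 3 to compound 4 is therefore expected to be none beyond the scatter. Compound 4 is expected to remain at the limit, estimated at 15000 nM with a range from 4000 nM to 60000 nM.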

Compound 4, half-maximal inhibitory concentration: > 10000 nM
Compound 4: no number, only a limit; the forecaster's own chance of this, stated with the estimate: 75%; the middle value is on the limit's open side.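

In this assay compound 4 gives > 10000 nM which is a limit of the assay and not a number. Its steps from compound 1, compound 2 and compound 3 therefore cannot be read in size: the limit of > 10000 nM in this assay, at which 4 of the 4 values shown sit. Still open, going by these compounds, is how far any of these four compounds lies past that limit.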